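The source may hold more compounds than are shown below. What is called first, only, known or untested is meant among the compounds shown, and "the series" means these compounds.

In a functional assay on SMMC-7721 cells (Homo sapiens) for antiproliferative activity, read by MTT assay, with a stated time of 48 h (a lower number here means a stronger inhibitor, a higher number a weaker inhibitor), compound 1 (`CC(C)=CCC[C@]1(C)/C=C/[C@@H](OC(=O)C=C(C)C)[C@](C)(O)/C=C/C(=O)/C(CCl)=C\C1`) gives 840 nM while compound 2 (`CC(C)=CCC[C@]1(C)/C=C/[C@@H](OC(=O)C=C(C)C)[C@](C)(O)/C=C/C(=O)/C(C[Si](C)(C)C(C)(C)C)=C\C1`) gives 4000 nM as the higher of the two numbers. Compound 3 (`CCN(CC)C(=O)/C1=C/C[C@](C)(CCC=C(C)C)/C=C/[C@@H](OC(=O)C=C(C)C)[C@](C)(O)/C=C/C1=O`) has not yet been measured. It differs from compound 2 by a group of 7 heavy atoms (5 carbon, 1 nitrogen, 1 oxygen; no ring) in place of a group of 8 heavy atoms (7 carbon, 1 silicon; no ring), on a double-bonded ring carbon and so carries a diethylcarbamoyl on a double-bonded ring carbon. For the measured compounds named here, only one measured step bears on this change, a 4.8-fold higher number from compound 1 to compound 2 (0.68 log units; beyond the scatter) and it is modest but beyond the scatter. Going by the values given here, that step exchanged a chlorine atom on a saturated chain carbon, whereas here the whole group on the ring carbon is replaced, and no compound with a diethylcarbamoyl has a measured value. The expected change is therefore small, a 1.6-fold lower number from compound 2 to compound 3 (0.20 log units; within the scatter) with a slight lean toward a lower number. Compound 3 is estimated in this assay at 2500 nM with an expected range of 800 nM to 8000 nM for this compound.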

Compound 3, half-maximal inhibitory concentration: 13800 nM
The estimate for compound 3 lay 5.5-fold (0.74 log units) below the measured number; measured number above the stated range.
By their numbers in this assay, from the lowest: compound 1; then compound 2; then compound 3.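

In this assay, replacing the silicon-bearing group on this double-bonded ring carbon with diethylcarbamoyl gives a 3.5-fold higher number from compound 2 to compound 3 (0.54 log units; beyond the scatter), and replacing chloromethyl with diethylcarbamoyl gives a 16-fold higher number from compound 1 to compound 3 (1.22 log units; beyond the scatter). The earlier pair showed a loss with one replacement of chloromethyl, whereas these steps show a second, larger loss with a group that contains no silicon and carries a hydrogen-bond acceptor, leaving compound 1 with the lowest number of the three, beyond the scatter from both others. Nothing available explains why the number rises with either group.

Going by these compounds, it remains open whether a hydroxymethyl, a carboxylic acid or a smaller amide such as dimethylcarbamoyl on this carbon would fall nearer compound 1 or compound 3. On these data alone, it is also open whether bromomethyl or another halogen-bearing methyl group would match chloromethyl.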